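The source may report more compounds than this note shows. Statements on the series, on what has been measured and on what is new or still open speak of the compounds shown alone.

Measured in an ADME assay on CEMx174 cells (Homo sapiens) for cytotoxicity; on this read-out lower numbers stand for higher toxicity in this test and higher numbers for lower toxicity in this test:
- compound 1 `CC1=C(C(=O)OCC2CCCCC2)C(c2cccc(O)c2)NC(=O)N1C`: > 10000 nM, a limit
- compound 2 `CC1=C(C(=O)OCC2CCCCC2)C(c2cccc(O)c2)N(C)C(=O)N1`: > 10000 nM, a limit
- compound 3 `CCCC1=C(C(=O)OCC2CCCCC2)C(c2cccc(O)c2)NC(=O)N1`: > 10000 nM, a limit

Compound 3 gives only a limit, not a number. Among the compounds with values here, the series so far sits at the limit of > 10000 nM in this assay, at which 3 of the 3 values shown sit, so compound 3 cannot be ranked within it.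

Compound 4 `O=C1NC(CCl)=C(C(=O)OCC2CCCCC2)C(c2cccc(O)c2)N1` differs from compound 3 in one place: chloro in place of ethyl on a saturated chain carbon bound to a double-bonded ring carbon. This is chloro in place of ethyl on a saturated chain carbon bound to a double-bonded ring carbon, or propyl to chloromethyl.

No measured step sizes this change. The expectation rests on compound 3 at > 10000 nM, which is a limit. No shift beyond the scatter is expected in this assay. The expected step is a number no higher from compound 3 to compound 4 (the limit leaves the size open). For compound 4 the estimate is 10000 nM, with an expected range of 3000 nM to 20000 nM.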

Compound 4, half-maximal cytotoxic concentration: > 3000 nM
Compound 4 gave a limit, no number; the forecaster's own chance of this, stated with the estimate: 70%; the middle value does not contradict the limit.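

Compound 3 and compound 4 each give only a limit in this assay, and no step can be read between them. The compounds shown leave open whether propyl to chloromethyl shifts this read-out at all.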